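Cyclopropyl in place of a silicon group on the alkyne carbon

The compounds below may be only part of what the source reports. "The series", "measured", "known", "first", "only" and "open" are said of these compounds alone.

compound 1 `C[Si](C)(C)C#Cc1c[nH]c(=O)[nH]c1=O`: 270000 nM
compound 2 `O=c1[nH]cc(C#CC(O)c2ccccc2)c(=O)[nH]1`: 242000 nM

In an ADME assay on Vero cells (Chlorocebus sabaeus) for cytotoxicity, read by MTT assay (a lower number here means that less compound is tolerated, a higher number that more compound is tolerated), compound 1 gives 270000 nM, the higher of the two numbers, though compound 2 with 242000 nM sits within the scatter of it. Compound 3 `O=c1[nH]cc(C#CC2CC2)c(=O)[nH]1` awaits measurement. It differs from compound 1 by a group of 3 heavy atoms (3 carbon; one three-membered non-aromatic ring of carbon only) in place of a group of 4 heavy atoms (3 carbon, 1 silicon; no ring), on a triple-bonded carbon. Among the compounds with values here, no step between measured compounds is known, so the expectation rests on compound 2, whose 242000 nM shows a different group at that carbon leaving the number near compound 1. The step is expected to be none beyond the scatter, a 1.1-fold lower number from compound 1 to compound 3 (0.03 log units; within the scatter). Compound 3 is thus estimated at 250000 nM, between 100000 nM and 600000 nM.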

Compound 3, half-maximal cytotoxic concentration: 252000 nM
The estimate for compound 3 lay 1.0-fold (0.00 log units) below the measured number; low and high end bracket the measured number.
By their numbers in this assay, from the lowest: compounds 2, 3 and 1 (each within the scatter of the next).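

Putting cyclopropyl in place of the silicon group on a triple-bonded carbon gives, in this assay, a 1.1-fold lower number from compound 1 to compound 3 (0.03 log units; within the scatter). This direct pairing shows that, for these two groups, removing silicon and adding a three-membered carbon ring does not separate the compounds beyond normal measurement variation. Nothing available explains this result.

From the compounds shown here alone, whether the tolerance seen here would hold with an amine or a carboxylic acid on that carbon remains open. So does the outcome with a longer carbon chain at the same position.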